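Working notes: from compound 2 to compound 4

This account rests on a few compounds, and the source may have more. Where it says the series, first, only, none or still open, it means among the compounds named here.

The three measured compounds share one core and vary at two places. In a functional assay on the whole organism (Pleural cavity) for inhibition, with Rattus norvegicus as the target, at a dose of 25 mg/kg (a higher number here means more inhibition at the dose given (going by the name of the read-out), a lower number less inhibition), compound 1 `CC1(Cc2ccccc2)C(=O)N(c2ccccc2)c2ncccc21` gives 9% and compound 3 `CC1(F)C(=O)N(c2ccccc2)c2ncccc21` gives 50%, while compound 2 `CSc1ccc(N2C(=O)C(C)(C)c3cccnc32)cc1` gives 29%, the second highest of the three numbers, beyond the scatter from both others. For the measured compounds named here, the only step between compounds differing in one place is a number 41 percentage points higher from compound 1 to compound 3 (beyond the scatter); it concerns a saturated ring carbon and does not bear on the change at hand. Compound 4 `CC(C)c1ccc(N2C(=O)C(C)(C)c3cccnc32)cc1` differs from compound 2 by isopropyl in place of methylsulfanyl on an aromatic carbon. Going by the values given here, no measured step touches this aromatic position, so no direction can be drawn from the data. The expected change is a number 2 percentage points lower from compound 2 to compound 4 (within the scatter), within the scatter. Compound 4 is estimated at 27%, with a range from 5% to 50%.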

Compound 4, a percentage reported as inhibition, in the whole organism at one dose (the size of the read-out at that dose, not a potency): 29%
Beside the measured number, compound 4's estimate is 2 percentage points below it; low and high end bracket the measured number.
By their numbers in this assay, from the lowest: compound 1; then compounds 2 and 4 (each within the scatter of the next); then compound 3.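

In this assay, isopropyl in place of methylsulfanyl gives no change at the digits printed from compound 2 to compound 4 (within the scatter). For the compounds shown here, this is the first measured step at this aromatic carbon, and it shows that, on this core, a sulfur-free group with no hydrogen-bond acceptor can replace methylsulfanyl without a change beyond the scatter. Nothing available explains this result.

The compounds shown leave open whether an amine or a carboxylic acid on this aromatic carbon would give a similar number. They also leave open whether this exchange would give the same result with the saturated ring carbon of compound 3.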